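The source may hold more compounds than are shown below. What is called first, only, known or untested is meant among the compounds shown, and "the series" means these compounds.

Working notes on the series.

Compound 1 `O=C(/C(=C\c1ccc(I)cc1)S(=O)(=O)c1ccc(Br)cc1)c1ccc(Br)cc1`, compound 2 `O=C(/C(=C\c1ccc(Cl)cc1Cl)S(=O)(=O)c1ccc(Br)cc1)c1ccc(Br)cc1` and compound 3 `O=C(/C(=C\c1ccc(Cl)cc1)S(=O)(=O)c1ccc(Br)cc1)c1ccc(Br)cc1` share one core and differ only in the aryl group on the double-bonded chain carbon. In a functional assay on DU-145 cells (Homo sapiens) for inhibition, read by trypan blue exclusion, with a stated time of 96 h (on this read-out lower numbers stand for stronger inhibition of growth and higher numbers for weaker inhibition of growth), compound 1 gives 1000 nM, compound 2 gives 10000 nM and compound 3 gives 50000 nM. Compound 3 therefore stands at the highest number of the three: the step of a 5.0-fold higher number from compound 2 to compound 3 (0.70 log units; beyond the scatter) and the step of a 50-fold higher number from compound 1 to compound 3 (1.70 log units; beyond the scatter) are both beyond the scatter, and compound 1 also moves by a 10-fold higher number from compound 1 to compound 2 (1.00 log units; beyond the scatter).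

Compound 4 `COc1cccc(OC)c1/C=C(\C(=O)c1ccc(Br)cc1)S(=O)(=O)c1ccc(Br)cc1` is not yet measured. It differs from compound 3 by 2,6-dimethoxyphenyl in place of 4-chlorophenyl on a double-bonded chain carbon bound to a double-bonded chain carbon. All three measured steps concern this same aryl group, so all bear on it, although none introduces a methoxy group and none puts two groups on that ring in the arrangement that enters here. The closest indication comes from compound 2 against compound 3, where a second substituent on that ring went with a lower number, a 5.0-fold higher number from compound 2 to compound 3 (0.70 log units; beyond the scatter) read in reverse; a modest step toward a lower number is therefore expected in this assay, but with wide uncertainty. For compound 4 the expected value in this assay is 15000 nM, within 3000 nM to 80000 nM, an expected step of a 3.3-fold lower number from compound 3 to compound 4 (0.52 log units; beyond the scatter).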

Compound 4, concentration for 50% growth inhibition: 10000 nM
Estimate against measurement, compound 4: 1.5-fold (0.18 log units) above, and the stated range covers the measured number.
By their numbers in this assay, from the lowest: compound 1; then compounds 2 and 4 (each within the scatter of the next); then compound 3.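

In this assay, for the compounds shown here, 2,6-dimethoxyphenyl on a double-bonded chain carbon bound to a double-bonded chain carbon gives a 5.0-fold lower number from compound 3 to compound 4 (0.70 log units; beyond the scatter), so a lower number than that of the 4-chlorophenyl compound is no longer seen only with a chloro-bearing ring. The two rings that carry two groups show no change at the digits printed from compound 2 to compound 4 (within the scatter), although their groups differ in kind, which suggests that this place accepts methoxy and chloro groups alike at this level of growth inhibition within these compounds. Neither ring matches 4-iodophenyl, as a 10-fold higher number from compound 1 to compound 4 (1.00 log units; beyond the scatter) shows, and compound 1 goes against any link between two groups on the ring and a lower number, since it carries one group and has the lowest number of the series; no data given here speak to the cause of these steps.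

The compounds shown leave open whether the level of compound 4 depends on having both methoxy groups, since a ring with a single methoxy group does not appear among them. They also leave open how an amine or a carboxylic acid on this ring would read in this assay, and whether any ring could match or pass 4-iodophenyl.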